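Alkynyl substituent change on the shared core

The source may hold more compounds than are shown below. What is called first, only, known or untested is meant among the compounds shown, and "the series" means these compounds.

Compound 2 `CNC(=O)[C@@]12C[C@@H]1[C@@H](n1cnc3c(NC)nc(C#Cc4cc5ccccc5o4)nc31)[C@H](O)[C@@H]2O` and compound 1 `CNC(=O)[C@@]12C[C@@H]1[C@@H](n1cnc3c(NC)nc(C#Cc4ccc(OC)cc4)nc31)[C@H](O)[C@@H]2O` differ only on the triple-bonded carbon. In an assay on CHO cells for displacement of a labelled ligand from adenosine receptor A3 (Homo sapiens), read by scintillation counting, with a stated time of 60 min (on this read-out higher numbers stand for weaker inhibition and lower numbers for stronger inhibition), compound 1 gives 0.63 nM and compound 2 gives 1.62 nM; the step of a 2.6-fold higher number from compound 1 to compound 2 (0.41 log units; beyond the scatter) puts compound 2 at the higher of the two numbers. Compound 3 `CNC(=O)[C@@]12C[C@@H]1[C@@H](n1cnc3c(NC)nc(C#CC4CC4)nc31)[C@H](O)[C@@H]2O` carries cyclopropyl in place of 1-benzofuran-2-yl on a triple-bonded carbon. Going by the values given here, only the step from compound 1 to compound 2 bears on this place, and that swap kept a five-membered aromatic ring; here it is lost for a three-membered ring, so a somewhat higher number is expected, a 3.1-fold higher number from compound 2 to compound 3 (0.49 log units; beyond the scatter). Compound 3 is estimated at 5 nM, range 1.5 nM to 20 nM.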

Compound 3, inhibition constant: 1.15 nM
Beside the measured number, compound 3's estimate is 4.3-fold (0.64 log units) above it; measured number below the stated range.
By their numbers in this assay, from the lowest: compounds 1, 3 and 2 (each within the scatter of the next, the first and the last beyond it).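

On the triple-bonded carbon, a small saturated ring reads much like the larger aromatic groups in this assay: replacing 1-benzofuran-2-yl with cyclopropyl gives (a 1.4-fold lower number from compound 2 to compound 3 (0.15 log units; within the scatter)), and replacing 4-methoxyphenyl with cyclopropyl gives (a 1.8-fold higher number from compound 1 to compound 3 (0.26 log units; within the scatter)). An aromatic ring on this carbon is therefore not needed for a low nanomolar number in this set, even though compound 1 and compound 2 remain apart beyond the scatter. Nothing available explains this result.

Open: whether an open-chain group such as tert-butyl, or a longer chain ending in an amine or a carboxylic acid, keeps the number in this range. The behaviour of these compounds at other adenosine receptors is also open.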